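Lengthening the acyl chain on a weak pyrazole amide

The compounds below may be only part of what the source reports. "The series", "measured", "known", "first", "only" and "open" are said of these compounds alone.

Compound 2 `O=C(Nc1cc(-c2ccccc2)nn1-c1ccccc1)C1CCCC1` is the weaker of the two measured compounds: in an assay on HEK293 cells for displacement of a labelled ligand from metabotropic glutamate receptor 5 (Rattus norvegicus) (a higher number here means a weaker inhibitor, a lower number a stronger inhibitor), compound 2 gives 11600 nM, the highest of the two numbers. Among the measured compounds shown here, its nearest neighbour is compound 1 `O=C(Nc1cc(-c2ccccc2)nn1-c1ccccc1)c1ccc(C(F)(F)F)cc1`, which in this assay gives 990 nM; the only measured step, a 12-fold higher number from compound 1 to compound 2 (1.07 log units; beyond the scatter), came from swapping the aryl group on the carbonyl carbon for a saturated ring. Compound 3 `O=C(CC1CCCC1)Nc1cc(-c2ccccc2)nn1-c1ccccc1` differs from compound 2 by a smaller change: cyclopentylmethyl in place of cyclopentyl on a carbonyl carbon, that is, one extra carbon between the ring and the carbonyl. For the measured compounds named here, no measured step speaks to this kind of one-carbon extension, so the large aryl-to-ring step gives no direct guide. The expectation is therefore a step of a 1.3-fold lower number from compound 2 to compound 3 (0.11 log units; within the scatter) that stays within the scatter. Compound 3 is estimated to give 9000 nM in this assay, within a range from 3000 nM to 30000 nM.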

Compound 3, inhibition constant: > 10000 nM
Compound 3 was reported as a limit; the forecaster's own chance of this, stated with the estimate: 25%; at least 1.1-fold (0.04 log units) between middle value and limit.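

Compound 3 is reported only as a limit, so the step from compound 2 cannot be read, and whether cyclopentylmethyl does better or worse than cyclopentyl stays undecided: the limit of > 10000 nM in this assay, at which 1 of the 3 values shown sits. The step that can be read is an at least 10-fold higher number from compound 1 to compound 3 (1.00 log units; beyond the scatter), with cyclopentylmethyl in place of 4-(trifluoromethyl)phenyl on a carbonyl carbon. The earlier pair showed such a loss for a single saturated group, and now both cyclopentyl in compound 2 and cyclopentylmethyl in compound 3 leave the amide well short of compound 1.

The compounds shown leave open whether a longer chain such as cyclopentylethyl, or an amine on the cyclopentyl ring, would give a readable value. Also open, on these data alone, is how a plain phenyl group, or a phenyl group carrying a nitrile in place of the trifluoromethyl group, compares with compound 1.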